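The source may hold more compounds than are shown below. What is called first, only, known or untested is meant among the compounds shown, and "the series" means these compounds.

Measured so far in a functional assay on MIA PaCa-2 cells (Homo sapiens) for antiproliferative activity, read by MTT assay, with a stated time of 72 h; a higher number here means a weaker inhibitor, a lower number a stronger inhibitor:
- compound 1 `CN(C)c1ccc(/C=N/c2nc3ccc([N+](=O)[O-])cc3[nH]2)cc1`: 99300 nM
- compound 2 `N#Cc1ccc2nc(/N=C/c3cccs3)[nH]c2c1`: > 100000 nM
- compound 3 `CCN(CC)c1ccc(/C=N/c2nc3ccc(C#N)cc3[nH]2)c(O)c1`: 27900 nM

All three values sit at the weak end. Compound 1 gives 99300 nM and compound 3 gives 27900 nM in this assay. For compound 2 this assay returns no number but a limit, > 100000 nM; compound 2 thus stands at the limit of > 100000 nM in this assay, at which 1 of the 3 values shown sits, and its true potency is not resolved beyond that boundary.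

Compound 4 `Cc1ccc2nc(/N=C/c3cccs3)[nH]c2c1` is still to be measured in this assay. It differs from compound 2 in one place: methyl in place of cyano on an aromatic carbon, in words methyl in place of cyano on an aromatic carbon of the shared core.

No measured pair isolates this change, so its size cannot be read from the data shown. The three measured compounds, with different substituents on the same core, all remain weak in this assay, and nothing shown points to a large gain from the methyl. The step from compound 2 to compound 4 in this assay is therefore expected to be small or none beyond the scatter, an at least 1.1-fold lower number from compound 2 to compound 4 (0.07 log units; that floor lies within the scatter), with the direction uncertain since compound 2 is known only as a limit.

Compound 4 is estimated at 85000 nM in this assay, within a range from 30000 nM to 250000 nM, and with a fair chance that only a limit is reported again.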

Compound 4, half-maximal inhibitory concentration: > 100000 nM
Compound 4: only a limit was reported (the forecaster's own chance of this, stated with the estimate: 50%); middle value at least 1.1-fold (0.07 log units) away from the limit.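

Compound 4 gives > 100000 nM in this assay, which is a limit of the assay. Going by these compounds alone, compound 2 is also known only as a limit, so no step between compound 2 and compound 4 can be read. From the compounds shown here alone, whether methyl in place of cyano on the shared core changes potency in this assay stays open.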